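Swapping a Nitrophenyl for a Fluorophenyl on Compound 2

A few compounds are considered here, and "the series" means these few. Any claim that something is new, unique, unknown or untested is made for them only; others in the source may bear on it.

Compound 1 `O=C(NC(=S)N1CCc2ccc(OCc3ccccc3)cc21)c1ccccc1` and compound 2 `O=C(NC(=S)N1CCc2c(OCCCCCOc3ccc(Cl)cc3)cccc21)c1cccc([N+](=O)[O-])c1` were both tested in an ADME assay on Huh-7 cells (Homo sapiens) for cytotoxicity; on this read-out lower numbers stand for higher toxicity in this test and higher numbers for lower toxicity in this test. Compound 1 gives 43800 nM there, while compound 2 gives 12100 nM, the lower of the two numbers, so compound 2 is the more toxic of the pair in this test; the gap between them is beyond the usual scatter. Compound 3 `O=C(NC(=S)N1CCc2c(OCCCCCOc3ccc(Cl)cc3)cccc21)c1ccc(F)cc1` has not yet been measured. It differs from compound 2 in one place: 4-fluorophenyl in place of 3-nitrophenyl on a carbonyl carbon. Among the measured compounds shown here, no measured pair shows this particular change, so there is no direct guide to its effect, and the expected step, a 1.2-fold higher number from compound 2 to compound 3 (0.09 log units; within the scatter), is one that stays within the scatter with no clear direction. In this assay compound 3 is therefore expected to give about 15000 nM, with a likely range from 6000 nM to 40000 nM.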

Compound 3, half-maximal cytotoxic concentration: 31100 nM
Beside the measured number, compound 3's estimate is 2.1-fold (0.32 log units) below it; the measured number falls inside the stated range.
By their numbers in this assay, from the lowest: compound 2; then compounds 3 and 1 (each within the scatter of the next).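

Compounds 1 and 2 differ in more than one place, so they could not show what the group on this carbonyl carbon does on its own. Compounds 2 and 3 can, as they differ in that group alone. 4-fluorophenyl in place of 3-nitrophenyl gives a 2.6-fold higher number from compound 2 to compound 3 (0.41 log units; beyond the scatter) in this assay, a modest step toward lower toxicity in this test. So the group at this position does influence the read-out, although nothing measured here explains why the number moves.

This swap changes both the substituent on the ring and its place on the ring, and the compounds shown cannot separate those two changes. They also leave open how this assay would read with an amine or a carboxylic acid on the ring at this position.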